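Ortho-Chloro on the Phenyl Ring of Compound 2

The source may hold more compounds than are shown below. What is called first, only, known or untested is meant among the compounds shown, and "the series" means these compounds.

Compound 1 `COCC(C(=O)N1CCN(c2cccc(C(F)(F)F)c2)CC1)N1C(=O)CCC1=O`: 100%
Compound 2 `CC(C(=O)N1CCN(c2ccccc2)CC1)N1C(=O)CCC1=O`: 50%
Compound 3 `CCC(C(=O)N1CCN(c2ccc(C(F)(F)F)cc2)CC1)N1C(=O)CCC1=O`: 0%

In a functional assay on the whole organism (strain Swiss) with Mus musculus as the target, in the maximal electroshock model, with a stated time of 1 h, at a dose of 300 mg/kg by the intraperitoneal route (a lower number here means a weaker effect, a higher number a stronger effect of the compound at the dose given), compound 2 gives 50%, the second highest of the three numbers. Compound 1 stands above it by a gap beyond the scatter, and compound 3 stands below it by a gap of the same size, also beyond the scatter. Compound 4 `CC(C(=O)N1CCN(c2ccccc2Cl)CC1)N1C(=O)CCC1=O` differs from compound 2 in one place: chloro in place of hydrogen on an aromatic carbon. Among the compounds with values here, no pair of measured compounds differs in this one place, so the size of the step is not known from the data. A step of modest size, within the scatter in either direction, is expected from compound 2 to compound 4, estimated as no change at the digits printed from compound 2 to compound 4 (within the scatter). Compound 4 is therefore expected to give about 50% in this assay, within a range from 10% to 90%.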

Compound 4, a percentage reported as activity, at one dose (the size of the read-out at that dose, not a potency): 25%
The estimate for compound 4 lay 25 percentage points above the measured number; low and high end bracket the measured number.
By their numbers in this assay, from the lowest: compound 3; then compound 4; then compound 2; then compound 1.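

In this assay, within the data shown here, chloro in place of hydrogen on this aromatic carbon gives a number 25 percentage points lower from compound 2 to compound 4 (beyond the scatter), the first comparison here between two compounds that differ in one place. It shows that, at the dose given, this position is not indifferent to the change: 2-chlorophenyl reads lower than phenyl. Nothing at hand explains the drop.

As far as these compounds go, whether fluoro, methyl or methoxy in place of the same hydrogen would read like chloro stays open. So does whether the step would carry over to a core with a longer chain.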